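Extending the side chain of compound 1 with a tert-butyl ester

The source may hold more compounds than are shown below. What is called first, only, known or untested is meant among the compounds shown, and "the series" means these compounds.

Compound 1 `C[C@@H]1N=C2C[C@@H]3C[C@@H](C3(C)C)[C@]2(C)OC1=O` is the weaker of the two measured compounds: in a functional assay on MCF7 cells (Homo sapiens) for antiproliferative activity, read by sulforhodamine B assay, with a stated time of 48 h (on this read-out lower numbers stand for stronger inhibition and higher numbers for weaker inhibition), compound 1 gives 154000 nM. Within the data shown here, its only measured neighbour is compound 2 `CC1(C)[C@@H]2CC3=NCC(=O)O[C@@]3(C)[C@H]1C2`, which in this assay gives 22000 nM; the step of a 7.0-fold lower number from compound 1 to compound 2 (0.85 log units; beyond the scatter) comes from hydrogen in place of methyl on a saturated ring carbon. Compound 3 `CC(C)(C)OC(=O)CC[C@@H]1N=C2C[C@@H]3C[C@@H](C3(C)C)[C@]2(C)OC1=O` differs from compound 1 in another place: (tert-butoxycarbonyl)methyl in place of hydrogen on a saturated chain carbon bound to a saturated ring carbon. Among the measured compounds shown here, no measured step touches that chain carbon, and the single step from compound 1 to compound 2 concerns a ring carbon instead, so it offers no direct guide. With nothing to point in either direction, compound 3 is expected to stay close to compound 1, with a step of a 1.4-fold lower number from compound 1 to compound 3 (0.15 log units; within the scatter) that is not expected to exceed the scatter. In this assay compound 3 is therefore estimated at 110000 nM, within a range of 30000 nM to 400000 nM.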

Compound 3, half-maximal inhibitory concentration: 40000 nM
Compound 3: the middle estimate sits 2.8-fold (0.44 log units) above what was measured; the measured number falls inside the stated range.
By their numbers in this assay, from the lowest: compounds 2 and 3 (each within the scatter of the next); then compound 1.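

The saturated chain carbon bound to a saturated ring carbon is the methyl carbon of compound 1, and in this assay adding (tert-butoxycarbonyl)methyl there gives a 3.9-fold lower number from compound 1 to compound 3 (0.59 log units; beyond the scatter), a modest change beyond the scatter. The same methyl, replaced by hydrogen, gives a 7.0-fold lower number from compound 1 to compound 2 (0.85 log units; beyond the scatter), so both removing this methyl and extending it lower the number, and compound 1 is the highest of the three. Nothing available explains either step.

The compounds shown leave open whether the lower number of compound 3 goes with the tert-butyl ester or with the chain itself. A free carboxylic acid, a methyl ester or a longer chain on this carbon would separate the two.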